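The compounds below may be only part of what the source reports. "The series", "measured", "known", "first", "only" and "open" are said of these compounds alone.

The series shares one core, shown in compound 1 `O=C(/C=C\c1cccc(O)c1)N1N=C(c2ccncc2)OC1c1c[nH]c2ccccc12`, which carries a 3-hydroxyphenyl on a double-bonded chain carbon bound to a double-bonded chain carbon. In an ADME assay on PANC-1 cells (Homo sapiens) for cytotoxicity, read by MTT assay, with a stated time of 48 h (on this read-out lower numbers stand for stronger inhibition of growth and higher numbers for weaker inhibition of growth), compound 1 gives only a limit of the assay, > 30 ug/mL. Compound 2 `O=C(/C=C\c1ccc([N+](=O)[O-])cc1)N1N=C(c2ccncc2)OC1c1c[nH]c2ccccc12`, with 4-nitrophenyl in place of 3-hydroxyphenyl, also returns a limit in this assay, > 30 ug/mL. Compound 3 `O=C(/C=C\c1ccccc1Cl)N1N=C(c2ccncc2)OC1c1c[nH]c2ccccc12`, with 2-chlorophenyl in that place, likewise stops at a limit in this assay, > 30 ug/mL. No step can be read: a step that the two limits leave unreadable from compound 1 to compound 2, a step that the two limits leave unreadable from compound 1 to compound 3 and a step that the two limits leave unreadable from compound 2 to compound 3 all lie between limits, and the limit of > 30 ug/mL in this assay, at which 3 of the 3 values shown sit, marks the point at which every value rests. Compound 3 therefore stands level with the other two as far as the numbers show, with nothing to rank.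

Compound 4 `O=C(/C=C\c1ccc(Br)cc1)N1N=C(c2ccncc2)OC1c1c[nH]c2ccccc12` differs from compound 3 in one place: 4-bromophenyl in place of 2-chlorophenyl on a double-bonded chain carbon bound to a double-bonded chain carbon. The three measured steps bear on it only in that each exchange of the aryl group left the read-out at the limit; none gives a size. For this assay the expected step is a step that the limit leaves unreadable from compound 3 to compound 4, none beyond the scatter. Compound 4 is therefore expected to give 40 ug/mL, with a range from 15 ug/mL to 100 ug/mL, most likely again reported only as a limit.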

Compound 4, concentration for 50% growth inhibition: > 30 ug/mL
Compound 4 was reported as a limit (the forecaster's own chance of this, stated with the estimate: 75%); the middle value lies beyond the limit too.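

In this assay compound 4 gives > 30 ug/mL, again a limit of the assay. Going by these compounds alone, no step from compound 1, compound 2 or compound 3 to compound 4 can be read, and all four compounds rest at one point: the limit of > 30 ug/mL in this assay, at which 4 of the 4 values shown sit. The compounds shown leave open how these aryl groups rank, and whether any of them gives a readable value on the shared core.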